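This account rests on a few compounds, and the source may have more. Where it says the series, first, only, none or still open, it means among the compounds named here.

Measured in a physicochemical assay for lipophilicity; a lower number here means a more polar compound, a higher number a more lipophilic compound:
compound 1 `CC1(C)CN(c2ccc3c(n2)NC(=O)CO3)[C@H](c2ccccc2)CO1`: 3.3
compound 2 `N#CC[C@@H]1CN(c2ccc3c(n2)NC(=O)CO3)[C@H](c2ccccc2)CO1`: 2.3
compound 3 `C[C@@H]1CN(c2ccc3c(n2)NC(=O)CO3)[C@H](c2ccccc2F)CO1`: 3.1

Across these three compounds, compound 3 gives 3.1. That number lies within the scatter of compound 1, and beyond the scatter above compound 2. Among the measured compounds shown here, the three share a core but differ in more than one place, so no measured step in this assay isolates a single change. Nothing in the series yet shows what a change on the phenyl group alone does.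

Compound 4 `C[C@@H]1CN(c2ccc3c(n2)NC(=O)CO3)[C@H](c2cccc(F)c2)CO1` is still to be measured. It carries 3-fluorophenyl in place of 2-fluorophenyl on a saturated ring carbon. The two compounds have the same atoms, joined differently, and the rest of the structure is unchanged.

For the measured compounds named here, with no measured precedent for this swap, the expectation is anchored on compound 3 at 3.1. No shift beyond the scatter is expected, at most a small rise. The estimated change is a number 0.10 log units higher from compound 3 to compound 4 (within the scatter). For compound 4 the expected value is 3.2, with an estimated range of 2.9 to 3.5.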

Compound 4, distribution coefficient: 3.1
Beside the measured number, compound 4's estimate is 0.10 log units above it; the measured number falls inside the stated range.
By their numbers in this assay, from the lowest: compound 2; then compounds 3, 4 and 1 (each within the scatter of the next).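

In this assay, the series now holds a step that changes one place only: 3-fluorophenyl in place of 2-fluorophenyl on the saturated ring carbon next to the ring nitrogen gives a clear reading (no change at the digits printed from compound 3 to compound 4 (within the scatter)). At this position, the two fluorophenyl groups cannot be told apart in this measurement, something compounds 1, 2 and 3 could not show, as they differ from one another in more than one place. No independent data here bear on why the two groups read alike.

Among the compounds shown here, the step covers only this one swap, so it is open whether a substituent of another kind on the phenyl ring, such as an amine or a carboxylic acid in place of the fluorine of 3-fluorophenyl, would shift the number beyond the scatter. For the compounds shown here, it is also open whether the same swap would read alike with the two methyl groups of compound 1 or the nitrile-bearing group of compound 2 in place of the single methyl group of compound 3 and compound 4.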